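Allenic amine series: para-methyl to para-methoxy in MAO inhibition

A few compounds are considered here, and "the series" means these few. Any claim that something is new, unique, unknown or untested is made for them only; others in the source may bear on it.

Compound 2 `C=C=C(CN)Cc1ccc(C)cc1` gives the lowest number of the two measured in an assay on isolated protein for inhibition of Monoamine oxidase (Rattus norvegicus) (on this read-out lower numbers stand for stronger inhibition and higher numbers for weaker inhibition), namely 1100 nM. Among the measured compounds shown here, its neighbour compound 1 `C=C=C(CN)Cc1ccccc1` gives 20000 nM in this assay, and the single measured step, an 18-fold lower number from compound 1 to compound 2 (1.26 log units; beyond the scatter), is the only one that bears on the aromatic substituent. Compound 3 `C=C=C(CN)Cc1ccc(OC)cc1` differs from compound 2 by methoxy in place of methyl on an aromatic carbon. For the measured compounds named here, no measured pair shows methoxy against methyl, so the step from methyl to methoxy has no direct precedent; the only guidance is that a small group in this position lowered the number strongly in the step from hydrogen to methyl. A change of the group rather than its presence is expected to matter less, so for compound 3 in this assay a step of a 1.4-fold higher number from compound 2 to compound 3 (0.13 log units; within the scatter) is expected, within the scatter. Compound 3 is therefore estimated at 1500 nM, with a range from 300 nM to 8000 nM.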

Compound 3, half-maximal inhibitory concentration: 700 nM
The estimate for compound 3 lay 2.1-fold (0.33 log units) above the measured number; the measured number falls inside the stated range.
By their numbers in this assay, from the lowest: compounds 3 and 2 (each within the scatter of the next); then compound 1.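

In this assay the large step seen with methyl is no longer tied to that one group: methoxy on this aromatic carbon also gives a large step, a 29-fold lower number from compound 1 to compound 3 (1.46 log units; beyond the scatter). The change between the two groups gives a 1.6-fold lower number from compound 2 to compound 3 (0.20 log units; within the scatter), so compound 2 and compound 3 cannot be ranked, and the oxygen and hydrogen-bond acceptor that enter with methoxy bring no readable difference here. Both substituted compounds thus stand apart from the unsubstituted compound 1, while methyl and methoxy remain indistinguishable in this assay; no evidence on hand bears on these results.

Still open, on these data alone, is whether the trend extends to a chlorine atom, an amine or a carboxylic acid on this carbon, or to a longer chain such as ethoxy. The compounds shown also leave open how methyl or methoxy would read on another aromatic carbon of the ring.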